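The source may hold more compounds than are shown below. What is called first, only, known or untested is meant among the compounds shown, and "the series" means these compounds.

Measured compounds in a functional assay on CHO cells for agonist activity at Alpha-1D adrenergic receptor (Homo sapiens), read by FLIPR and calcium flux; a higher number here means that more compound is needed for the effect, a lower number that less compound is needed:
compound 1, `c1cc(-c2cn[nH]c2)c2c(c1)C(c1ncc[nH]1)CC2`: 319 nM
compound 2, `Cn1ccc(-c2cccc3c2CCC3c2ncc[nH]2)n1`: a limit of the assay, > 10000 nM
compound 3, `c1cc(-c2ncco2)c2c(c1)C(c1ncc[nH]1)CC2`: 1390 nM

Compound 3 gives the highest of the two numbers; compound 1 is nearest, and the step is a 4.4-fold higher number from compound 1 to compound 3 (0.64 log units; beyond the scatter). For compound 2 only a limit is known, (the limit of > 10000 nM in this assay, at which 1 of the 3 values shown sits). The unmeasured compound 4, `COc1cccc2c1CCC2c1ncc[nH]1`, differs from compound 3 in one place: methoxy in place of 1,3-oxazol-2-yl on an aromatic carbon. The steps measured so far all swap one five-membered aromatic ring for another on the shared core: a 4.4-fold higher number from compound 1 to compound 3 (0.64 log units; beyond the scatter) was modest, while an at least 31-fold higher number from compound 1 to compound 2 (1.49 log units; beyond the scatter) and an at least 7.1-fold lower number from compound 2 to compound 3 (0.85 log units; beyond the scatter) were larger. Going by the values given here, no measured step removes the pendant ring altogether, so the direction is uncertain; a step beyond the scatter toward a higher number is expected, a 2.5-fold higher number from compound 3 to compound 4 (0.40 log units; beyond the scatter). Compound 4 is therefore estimated at 3500 nM, with a range from 900 nM to 15000 nM.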

Compound 4, half-maximal effective concentration: > 10000 nM
Compound 4 was reported as a limit; the forecaster's own chance of this, stated with the estimate: 30%; at least 2.8-fold (0.45 log units) between middle value and limit.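

Methoxy is the only group without a ring shown on this aromatic carbon, and it gives an at least 7.1-fold higher number from compound 3 to compound 4 (0.85 log units; beyond the scatter) and an at least 31-fold higher number from compound 1 to compound 4 (1.49 log units; beyond the scatter). The two compounds with measured numbers, compound 1 and compound 3, both carry a five-membered aromatic ring here, but compound 2 goes against any rule that such a ring is enough. Compound 4 gives a limit of the assay, as does compound 2, and the step between them cannot be read: the limit of > 10000 nM in this assay, at which 2 of the 4 values shown sit.

Going by these compounds, whether an amine, a hydroxyl group or a longer chain at this place would give a measurable number stays open. So does the result for the shared core with plain hydrogen on this carbon.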